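A few compounds are considered here, and "the series" means these few. Any claim that something is new, unique, unknown or untested is made for them only; others in the source may bear on it.

Measured compounds:
compound 1 `COc1cc2c(cc1OC)CN(S(=O)(=O)c1ccc(-n3cc(COc4ccc(C=O)cc4)nn3)cc1)CC2` gives 12500 nM
compound 2 `COc1cc2c(cc1OC)CN(S(=O)(=O)c1ccc(-n3cc(COc4ccc5ccccc5c4)nn3)cc1)CC2` gives 1260 nM
compound 3 `O=S(=O)(c1ccc(-n2cc(COc3ccccc3)nn2)cc1)N1CCc2ccccc2C1` gives 6500 nM

All three were tested in a functional assay on HepG2 cells (Homo sapiens) for cytotoxicity, read by MTT assay, with a stated time of 48 h; a lower number here means a stronger inhibitor, a higher number a weaker inhibitor. Among them compound 1 has the highest number; compound 3 sits closest, and its value and that of compound 1 lie within the scatter of each other, so no order between the two can be read. Compound 2 lies furthest away, with the step of a 9.9-fold lower number from compound 1 to compound 2 (1.00 log units; beyond the scatter), a modest change that goes beyond the scatter.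

Compound 4 `COc1cc2c(cc1OC)CN(S(=O)(=O)c1ccc(-n3cc(COc4ccccc4)nn3)cc1)CC2` is not yet measured. It differs from compound 1 in one place: hydrogen in place of formyl on an aromatic carbon. The change sits on an aromatic carbon of a six-membered aromatic ring of carbon only, para to a large group; read one bond further out, it is 4-formylphenyl to phenyl.

Among the compounds with values here, the only measured step touching this position is the one from compound 1 to compound 2, where a larger ring system replaced the 4-formylphenyl and the number dropped. Within the data shown here, compound 3 carries a plain phenoxy like compound 4 but on a different core, so no step can be drawn between them; its value simply shows what a phenoxy arm can give. On this basis compound 4 is expected to show a small drop, a 2.1-fold lower number from compound 1 to compound 4 (0.32 log units; beyond the scatter), and its value in this assay is estimated at 6000 nM, within 2000 nM to 18000 nM.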

Compound 4, half-maximal inhibitory concentration: 2570 nM
Compound 4: middle estimate off by 2.3-fold (0.37 log units), on the high side, and the stated range covers the measured number.
By their numbers in this assay, from the lowest: compound 2; then compound 4; then compounds 3 and 1 (each within the scatter of the next).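

In this assay, taking away the formyl alone and leaving a plain phenoxy arm gives a 4.9-fold lower number from compound 1 to compound 4 (0.69 log units; beyond the scatter), so this single group on the aromatic carbon carries a clear part of the difference. The earlier step swapped the whole 4-formylphenyl for naphthalen-2-yl, so it could not separate losing the formyl from gaining a larger ring system. The new comparison pulls these two apart: a 2.0-fold higher number from compound 2 to compound 4 (0.31 log units; beyond the scatter) shows that the phenyl arm without a formyl still does not reach the number of the naphthalen-2-yl arm, so both changes count in this small set, and nothing available explains why either one shifts the cell result.

The compounds shown leave open whether it is the formyl itself that matters, since only hydrogen stands in its place, and another group on this aromatic carbon, para to a large group, such as a hydroxymethyl, a carboxylic acid or an amine, could show how the number responds. They also leave open whether the effect of removing the formyl would carry over to the core of compound 3.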